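The compounds below may be only part of what the source reports. "The series", "measured", "known", "first", "only" and "open" are said of these compounds alone.

Compound 1 `CC(C)CC(=O)Nc1ncc(-c2cccc(Cl)c2)c(-c2ccccc2)n1` gives 56% in an assay on CHO cells for displacement of a labelled ligand from adenosine receptor A1 (Homo sapiens), read by scintillation counting, with a stated time of 1 h, tested at 1 uM; a higher number here means more inhibition at the concentration tested (going by the name of the read-out), a lower number less inhibition. Compound 2 `Clc1cccc(-c2cnc(NC3CCCC3)nc2-c2ccccc2)c1` reports only a limit of this assay, > 80%, rather than a number (the limit of > 80% in this assay, at which 1 of the 2 values shown sits). Among the measured compounds shown here, the single measured step, a number at least 24 percentage points higher from compound 1 to compound 2 (beyond the scatter), is the one that bears on compound 3 `CNc1ncc(-c2cccc(Cl)c2)c(-c2ccccc2)n1`, which differs from compound 2 by methyl in place of cyclopentyl on a nitrogen on an aromatic ring. Because a number at least 24 percentage points higher from compound 1 to compound 2 (beyond the scatter) came with the cyclopentyl entering, its replacement by methyl is expected to lower inhibition, by an estimated a number at least 40 percentage points lower from compound 2 to compound 3 (beyond the scatter). Compound 3 is therefore estimated at 40%, within a range from 15% to 70%.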

Compound 3, a percentage reported as inhibition, at one concentration (the size of the read-out at that concentration, not a potency): 75%
Compound 3: middle estimate off by 35 percentage points, on the low side; measured number outside the range, above it.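

In this assay, methyl in place of cyclopentyl on a nitrogen on an aromatic ring gives a number at least 5 percentage points lower from compound 2 to compound 3 (that floor lies within the scatter), so the cyclopentyl ring is not shown to be needed for most of the inhibition. Methyl in place of isobutylcarbonyl gives a number 19 percentage points higher from compound 1 to compound 3 (beyond the scatter), so even this single carbon outdoes the group on compound 1. The full size of the step from cyclopentyl to methyl stays unread, for compound 2 carries only a limit: the limit of > 80% in this assay, at which 1 of the 3 values shown sits.

Open, from the compounds shown here alone, is how an ethyl, a cyclohexyl or an unsubstituted amino group on this nitrogen would read. An acetyl there would show whether the carbonyl itself goes with the lower number of compound 1.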